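This account rests on a few compounds, and the source may have more. Where it says the series, first, only, none or still open, it means among the compounds named here.

Two compounds of this series have been run in a functional assay on the whole organism (strain Wistar albino) for inhibition, with Rattus norvegicus as the target, read by paw edema, with stated times of 30 min and 2 h, at a dose of 20 mg/kg; a higher number here means more inhibition at the dose given (going by the name of the read-out), a lower number less inhibition. Compound 1 `Cc1ccc([C@H]2CC(c3ccccc3)=NN2c2ncc(Br)cn2)cc1` gives 69% in this assay. Compound 2 `Clc1ccc([C@H]2CC(c3ccccc3)=NN2c2ncc(Br)cn2)cc1` gives 76% in this assay; the step of a number 7 percentage points higher from compound 1 to compound 2 (within the scatter) is chloro in place of methyl on an aromatic carbon. Compound 2 thus stands alongside compound 1, the two values within the scatter of each other. Going by the values given here, compound 3 `Brc1ccc([C@H]2CC(c3ccccc3)=NN2c2ncc(Br)cn2)cc1` is not yet measured. bromo in place of chloro on an aromatic carbon The only measured step, a number 7 percentage points higher from compound 1 to compound 2 (within the scatter), stayed within the scatter; it exchanged methyl for chloro, not chloro for bromo, and bears on this change only loosely. Nothing in the series points to a move beyond the scatter for compound 3, so the step is expected to be small, no change at the digits printed from compound 2 to compound 3 (within the scatter). Compound 3 is therefore estimated at 76% in this assay, within a range from 62% to 88%.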

Compound 3, a percentage reported as inhibition, in the whole organism at one dose (the size of the read-out at that dose, not a potency): 74%
Compound 3: middle estimate off by 2 percentage points, on the high side, within the range that was stated.
By their numbers in this assay, from the lowest: compounds 1, 3 and 2 (each within the scatter of the next).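

At the place para to a large group, the second halogen gives a third comparison in this assay: the exchange of chloro for bromo gives a number 2 percentage points lower from compound 2 to compound 3 (within the scatter) and the exchange of methyl for bromo gives a number 5 percentage points higher from compound 1 to compound 3 (within the scatter) in this series. Methyl, chloro and bromo at this place now all lie within the scatter of one another, so the single earlier step is no longer the only sign of a flat stretch, although that holds for these three groups only. No measured evidence bears on why these values stay so close.

On these data alone, whether an amine, a carboxylic acid or a longer chain at this place would move the read-out beyond the scatter remains open. Changes elsewhere on the shared core are also open, as is how these compounds compare at any other dose.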